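Removing the Chloro from the Benzamide of Compound 1

The source may hold more compounds than are shown below. What is called first, only, known or untested is meant among the compounds shown, and "the series" means these compounds.

Compound 1 `NC(=O)c1c(NC(=O)c2ccccc2Cl)sc2c1CCN(C(=S)Nc1ccccc1)C2` gives 5940 nM in a functional assay on HL-60 cells (Homo sapiens) for antiproliferative activity, with a stated time of 24 h (on this read-out lower numbers stand for stronger inhibition and higher numbers for weaker inhibition), the lowest of the three numbers measured, though only its step to compound 2 lies beyond the scatter. Compound 2 `CSc1ccccc1NC(=S)N1CCc2c(sc(NC(=O)c3ccccc3Cl)c2C(N)=O)C1` gives 14600 nM and compound 3 `NC(=O)c1c(NC(=O)c2ccccc2Cl)sc2c1CCN(C(=S)Nc1ccc(C(F)(F)F)cc1)C2` gives 7590 nM. The step of a 2.5-fold higher number from compound 1 to compound 2 (0.39 log units; beyond the scatter) is modest; the steps of a 1.3-fold higher number from compound 1 to compound 3 (0.11 log units; within the scatter) and a 1.9-fold lower number from compound 2 to compound 3 (0.28 log units; within the scatter) stay within the scatter. Compound 4 `NC(=O)c1c(NC(=O)c2ccccc2)sc2c1CCN(C(=S)Nc1ccccc1)C2` differs from compound 1 in hydrogen in place of chloro on an aromatic carbon, so that 2-chlorophenyl becomes phenyl. Within the data shown here, none of the measured steps touches this part of the molecule; all three alter the aryl on the thiourea, and none exceeded modest size. Compound 4 is therefore expected to give 7500 nM (between 2500 nM and 22000 nM). The step of a 1.3-fold higher number from compound 1 to compound 4 (0.10 log units; within the scatter) is expected to remain within the scatter.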

Compound 4, half-maximal inhibitory concentration: > 50000 nM
Compound 4: no number, only a limit; the forecaster's own chance of this, stated with the estimate: 10%; at least 6.6-fold (0.82 log units) between middle value and limit.
By their numbers in this assay, from the lowest: compounds 1, 3 and 2 (each within the scatter of the next, the first and the last beyond it). At a limit, above all of these: compound 4.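

In this assay compound 4 carries a limit of the assay and not a number: the limit of > 50000 nM in this assay, at which 1 of the 4 values shown sits. Taking the chloro away from the 2-chlorophenyl gives an at least 8.4-fold higher number from compound 1 to compound 4 (0.92 log units; beyond the scatter), the largest step shown, whereas the earlier steps all altered the aryl on the thiourea. This place on the benzamide ring, ortho to a large group, therefore weighs more on the read-out than those changes did. On these data alone, whether chloro itself is required remains open, since a fluoro, bromo or methyl group here would show if other substituents can serve. As far as these compounds go, the full size of the step also remains open.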